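A few compounds are considered here, and "the series" means these few. Any claim that something is new, unique, unknown or untested is made for them only; others in the source may bear on it.

The three measured compounds share one core and differ only in the aryl group sitting on a double-bonded chain carbon bound to a double-bonded chain carbon and a saturated chain carbon. Compound 1 `CC/C(=C(/c1ccc(/C=C/C(=O)O)cc1)c1cc2ccccc2[nH]1)c1ccccc1C(F)(F)F` carries 2-(trifluoromethyl)phenyl there; in a functional assay on MCF7 cells (Homo sapiens) for inhibition (on this read-out lower numbers stand for stronger inhibition and higher numbers for weaker inhibition), compound 1 gives 8 nM. Compound 2 `CC/C(=C(/c1ccc(/C=C/C(=O)O)cc1)c1cc2ccccc2[nH]1)c1cccc(C(F)(F)F)c1` carries 3-(trifluoromethyl)phenyl instead, and in this assay compound 2 gives 325 nM, a change of a 41-fold higher number from compound 1 to compound 2 (1.61 log units; beyond the scatter). Compound 3 `CC/C(=C(/c1ccc(/C=C/C(=O)O)cc1)c1cc2ccccc2[nH]1)c1cccc(OC(F)(F)F)c1` carries 3-(trifluoromethoxy)phenyl, and in this assay compound 3 gives 282 nM. Compound 3 thus stands second highest of the three numbers: the step of a 1.2-fold lower number from compound 2 to compound 3 (0.06 log units; within the scatter) is within the scatter, while the step of a 35-fold higher number from compound 1 to compound 3 (1.55 log units; beyond the scatter) is large.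

Compound 4 `CC/C(=C(/c1ccc(/C=C/C(=O)O)cc1)c1cc2ccccc2[nH]1)c1ccc(C#N)cc1` is the next variation: 4-cyanophenyl in place of 3-(trifluoromethoxy)phenyl on a double-bonded chain carbon bound to a double-bonded chain carbon and a saturated chain carbon. For the measured compounds named here, the steps that bear on it show that the aryl group matters strongly: a 35-fold higher number from compound 1 to compound 3 (1.55 log units; beyond the scatter) and a 41-fold higher number from compound 1 to compound 2 (1.61 log units; beyond the scatter) both moved the number far, whereas exchanging trifluoromethoxy for trifluoromethyl, a 1.2-fold lower number from compound 2 to compound 3 (0.06 log units; within the scatter), changed little. Going by the values given here, no measured step shows what 4-cyanophenyl does at this place. The expected step is therefore modest, a 1.9-fold lower number from compound 3 to compound 4 (0.27 log units; within the scatter), toward a lower number, with wide uncertainty. Compound 4 is estimated at 150 nM, between 30 nM and 800 nM.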

Compound 4, half-maximal inhibitory concentration: 278 nM
For compound 4 the middle estimate is 1.9-fold (0.27 log units) below the measured one; the range from low to high includes it.
By their numbers in this assay, from the lowest: compound 1; then compounds 4, 3 and 2 (each within the scatter of the next).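

In this assay the step of a 1.0-fold lower number from compound 3 to compound 4 (0.01 log units; within the scatter) and the step of a 1.2-fold lower number from compound 2 to compound 4 (0.07 log units; within the scatter) both stay within the scatter, so 4-cyanophenyl cannot be told apart from 3-(trifluoromethoxy)phenyl or 3-(trifluoromethyl)phenyl at this place. This widens the earlier picture: the level shared by compound 2 and compound 3 also holds for an aryl group with a nitrile and a differently numbered substituent, even though the group entering is smaller, with fewer heavy atoms than the one leaving. Compound 1 remains the one exception among the four, and the step of a 35-fold higher number from compound 1 to compound 4 (1.54 log units; beyond the scatter) is about as large as the steps that separate it from compound 2 and compound 3, but nothing measured here explains either this gap or the match among the other three.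

As far as these compounds go, what remains open is whether the low number of compound 1 depends on trifluoromethyl itself or would also appear with 2-cyanophenyl or 2-(trifluoromethoxy)phenyl at this place. From the compounds shown here alone, it is equally open whether 4-(trifluoromethyl)phenyl would join the level of compound 2, compound 3 and compound 4, and how an aryl group carrying an amine or a carboxylic acid would behave here.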